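A Chloro Swap Tested for Cell Toxicity

A few compounds are considered here, and "the series" means these few. Any claim that something is new, unique, unknown or untested is made for them only; others in the source may bear on it.

Of the compounds shown here, two have values so far in an ADME assay on HEK293 cells (Homo sapiens) for cytotoxicity, read by resazurin assay, with a stated time of 24 h; on this read-out higher numbers stand for weaker inhibition and lower numbers for stronger inhibition. There, compound 1 `N=C(N)c1ccc(NC(=O)Nc2ccc(C(=N)N)cc2)cc1` gives 266000 nM and compound 2 `COCc1c(-c2ccc(C(=N)N)cc2)oc(-c2ccc(C(=N)N)cc2)c1Cl` gives 209000 nM. These two values lie within the usual scatter of each other, so compound 2 cannot be ranked against compound 1 on these numbers.

Compound 3 `COCc1c(-c2ccc(C(=N)N)cc2)oc(-c2ccc(C(=N)N)cc2)c1COC` keeps the core of compound 2, with methoxymethyl in place of chloro on an aromatic carbon. Among the measured compounds shown here, no pair of measured compounds differing in one place exists yet, so the data offer no direct guide to what such a swap does. For the measured compounds named here, the only close reference is compound 2 at 209000 nM, and no change beyond the scatter is expected in this assay. The estimate implies a 1.1-fold higher number from compound 2 to compound 3 (0.04 log units; within the scatter), an expected step within the scatter. For compound 3 the estimated value is 230000 nM, with an expected range from 100000 nM to 450000 nM.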

Compound 3, half-maximal inhibitory concentration: > 50000 nM
Compound 3: only a limit was reported; the forecaster's own chance of this, stated with the estimate: 15%; the middle value does not contradict the limit.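

In this assay, among the compounds shown here, compound 3 carries only a limit of > 50000 nM and not a number, so no step from compound 2 to compound 3 can be read. The compounds shown leave open whether methoxymethyl in place of chloro changes this reading at all.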